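Swapping phenyl for ethyl on an inactive urea

A few compounds are considered here, and "the series" means these few. Any claim that something is new, unique, unknown or untested is made for them only; others in the source may bear on it.

Compound 1 `O=C(NCCCCc1ccccc1)n1nnc2ncccc21`: 1.3 nM
Compound 2 `O=C(NCCCCc1ccccc1)Nc1nc2ccccc2s1`: > 10000 nM

Of the compounds shown here, two have been measured in an assay on HEK293 cells for inhibition of acid ceramidase (Homo sapiens), read by fluorescence, with stated times of 30 min and 1 h; on this read-out higher numbers stand for weaker inhibition and lower numbers for stronger inhibition. Compound 1 gives 1.3 nM in this assay. For compound 2 the result is not a number but a limit of the assay, > 10000 nM. From the compounds shown here alone, compound 2 therefore stands at the limit of > 10000 nM in this assay, at which 1 of the 2 values shown sits, and how far beyond that limit it lies is unknown.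

Compound 3 `CCCCCCNC(=O)Nc1nc2ccccc2s1` has not been measured. It differs from compound 2 in one place: ethyl in place of phenyl on a saturated chain carbon, four bonds along the chain from an amide-type nitrogen. Within the data shown here, no measured pair of compounds shows what such a change does here. Since compound 2 is only known to lie at the limit, the step from compound 2 to compound 3 in this assay is expected to be small, a step that the limit leaves unreadable from compound 2 to compound 3, within the scatter. Compound 3 is expected to give about 20000 nM, with a range from 5000 nM to 100000 nM, most likely again reported as a limit.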

Compound 3, half-maximal inhibitory concentration: > 10000 nM
Compound 3: only a limit was reported (the forecaster's own chance of this, stated with the estimate: 85%); the middle value is on the limit's open side.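

In this assay, among these compounds, compound 2 and compound 3 are both reported only as a limit of the assay, so no step between them can be read. The compounds shown leave open how far past that limit each lies, and whether exchanging phenyl for ethyl changes inhibition at all.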